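A few compounds are considered here, and "the series" means these few. Any claim that something is new, unique, unknown or untested is made for them only; others in the source may bear on it.

Compound 1 `c1ccc(CN(CCCN2CCCCC2)c2cc(-c3ccccc3)no2)cc1` gives 9000 nM in a functional assay for antagonist activity at proteinase-activated receptor 1 (Homo sapiens); a lower number here means a stronger inhibitor, a higher number a weaker inhibitor.
Compound 2 `c1ccc(-c2cc(N(CCCN3CCCCC3)CC3CCCCC3)on2)cc1` gives > 10000 nM in this assay; this is a limit of the assay, not a number.

Compound 2 therefore sits at the limit of > 10000 nM in this assay, at which 1 of the 2 values shown sits, and only a limit is known for it. Going by the values given here, the one measured step, an at least 1.1-fold higher number from compound 1 to compound 2 (0.04 log units; that floor lies within the scatter), was cyclohexyl in place of phenyl on a saturated chain carbon bound to a nitrogen on an aromatic ring. Compound 3 `c1ccc(-c2cc(N(CCCN3CCCCC3)Cc3cccc4ccccc34)on2)cc1` arises through (naphthalen-1-yl in place of cyclohexyl on a saturated chain carbon bound to a nitrogen on an aromatic ring), returning to an aromatic group, now larger. That measured step gives little guidance for its size. Compound 3 is expected to reach 5000 nM, between 1500 nM and 20000 nM, so that an at least 2.0-fold lower number from compound 2 to compound 3 (0.30 log units; that floor lies within the scatter) is estimated.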

Compound 3, half-maximal inhibitory concentration: 500 nM
Compound 3: the middle estimate sits 10-fold (1.00 log units) above what was measured; measured number below the stated range.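

Compound 3 shows that the group on a saturated chain carbon bound to a nitrogen on an aromatic ring can shift the result in this assay well beyond the scatter. The change to naphthalen-1-yl brings an 18-fold lower number from compound 1 to compound 3 (1.26 log units; beyond the scatter) when it replaces phenyl, and an at least 20-fold lower number from compound 2 to compound 3 (1.30 log units; beyond the scatter) when it replaces cyclohexyl. The second step starts from a limit: compound 2 stands at > 10000 nM and this is a limit of the assay, not a number.

The compounds shown leave open whether naphthalen-2-yl, or a phenyl carrying a methoxy group, would serve as well as naphthalen-1-yl at this place.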